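The source may report more compounds than this note shows. Statements on the series, on what has been measured and on what is new or still open speak of the compounds shown alone.

Among the three measured compounds, compound 3 `Cc1ccc(OCC(=O)N(Cc2cccs2)c2ccn(C)n2)cc1` stands second highest in an assay on HEK293 cells for agonist activity at transient receptor potential cation channel subfamily M member 8 (Homo sapiens), read by fluorescence and calcium flux, with a stated time of 15 min (on this read-out lower numbers stand for an effect already at smaller amounts and higher numbers for an effect only at larger amounts of compound), where compound 3 gives 855 nM. Compound 2 `C=CCN(Cc1cccs1)C(=O)COc1ccc(C)cc1` gives 20 nM, and compound 1 `Cc1ccc(OCC(=O)N(CCCO)Cc2cccs2)cc1` gives 3000 nM. The step to compound 4 `Cc1ccc(OCC(=O)N(O)Cc2cccs2)cc1` is hydroxy in place of 1-methyl-1H-pyrazol-3-yl on an amide-type nitrogen. For the measured compounds named here, two measured steps bear on it: a 3.5-fold lower number from compound 1 to compound 3 (0.55 log units; beyond the scatter) and a 43-fold higher number from compound 2 to compound 3 (1.63 log units; beyond the scatter). Going by the values given here, the pyrazolyl thus did better than the hydroxy-bearing chain of compound 1 and worse than the allyl of compound 2; the only measured compound carrying a hydroxy group on that nitrogen's side, compound 1, gave 3000 nM. For compound 4 the expected step is a 5.8-fold higher number from compound 3 to compound 4 (0.77 log units; beyond the scatter). Compound 4 is expected to give 5000 nM, with a range from 1000 nM to 25000 nM.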

Compound 4, half-maximal effective concentration: 8000 nM
Compound 4: the middle estimate sits 1.6-fold (0.20 log units) below what was measured; the range from low to high includes it.
By their numbers in this assay, from the lowest: compound 2; then compound 3; then compound 1; then compound 4.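

In this assay, hydroxy directly on the amide-type nitrogen gives the highest number of the series, with a 9.4-fold higher number from compound 3 to compound 4 (0.97 log units; beyond the scatter), a 2.7-fold higher number from compound 1 to compound 4 (0.43 log units; beyond the scatter) and a 400-fold higher number from compound 2 to compound 4 (2.60 log units; beyond the scatter). The two compounds carrying hydroxy, compound 1 and compound 4, now stand highest, although compound 3 has no hydroxy and also lies well above compound 2. No measurement shown here accounts for these steps. Going by these compounds, it remains open whether a plain propyl chain or a methoxy group on this nitrogen would stay near compound 2 or move toward compound 4.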